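The source may report more compounds than this note shows. Statements on the series, on what has been measured and on what is new or still open speak of the compounds shown alone.

Measured so far:
- compound 1, `COc1ccc(/C=C2\CCC/C(=C\c3ccc([N+](=O)[O-])cc3)C2=O)cc1`: 5.08
- compound 2, `COc1cc(/C=C2\CCC/C(=C\c3ccccc3[N+](=O)[O-])C2=O)cc(OC)c1OC`: 4.86
- compound 3, `Cc1ccc(/C=C2\CCC/C(=C\c3cccc([N+](=O)[O-])c3)C2=O)cc1`: 5.06

All three numbers come from a physicochemical assay for lipophilicity; a higher number here means a more lipophilic compound, a lower number a more polar compound. Compound 1 holds the highest of the three partition coefficients, yet the spread is narrow: compound 3 sits a shade lower and compound 2 furthest away, and both gaps fall within the usual scatter of this assay, so no order among the three can be read from them.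

The next compound, compound 4, `O=C1/C(=C/c2ccc(F)cc2)CCC/C1=C\c1ccc([N+](=O)[O-])cc1`, has not been measured. Against compound 1 it shows one change: fluoro in place of methoxy on an aromatic carbon. Cut one bond further out this reads as 4-methoxyphenyl to 4-fluorophenyl, the place being an aromatic carbon para to a large group on the shared core. Among the measured compounds shown here, no pair of measured compounds differs in exactly this way, so the step has no precedent here.

For this assay the change is expected to move the partition coefficient only a little, if at all, toward the more lipophilic side, the expected step from compound 1 to compound 4 being a number 0.12 log units higher from compound 1 to compound 4 (within the scatter), which stays within the scatter. Compound 4 is therefore estimated at 5.2, with a range from 4.9 to 5.5.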

Compound 4, partition coefficient: 5.08
For compound 4 the middle estimate is 0.12 log units above the measured one; measured number inside the range.
By their numbers in this assay, from the lowest: compounds 2, 3, 1 and 4 (each within the scatter of the next).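

In this assay, among the compounds shown here, fluoro in place of methoxy on an aromatic carbon para to a large group gives no change at the digits printed from compound 1 to compound 4 (within the scatter), and this is the first comparison that isolates one place, since compounds 1, 2 and 3 do not differ from one another in a single place. At this position, 4-methoxyphenyl and 4-fluorophenyl therefore cannot be told apart by this read-out, even though the exchange takes the substituent from 2 heavy atoms and 1 hydrogen-bond acceptor to 1 heavy atom and 0 hydrogen-bond acceptors. No measurement available here accounts for the two groups reading alike.

Going by these compounds, whether a group further removed from these two, such as an amine, a carboxylic acid or a longer chain, would move the partition coefficient beyond the scatter at this same place remains open. This single pair also leaves open whether fluoro in place of methoxy would read the same elsewhere on the shared core or alongside a different partner substituent, so no general rule follows from it.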